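This account rests on a few compounds, and the source may have more. Where it says the series, first, only, none or still open, it means among the compounds named here.

Of the compounds shown here, two built on one shared core have been measured for how well they dissolve. In a physicochemical assay for solubility, read by spectrophotometry, in phosphate buffer, with a stated time of 18 h, at pH 7.4 (on this read-out higher numbers stand for higher solubility and lower numbers for lower solubility), compound 1 `CCc1ccc(-c2nc3c(c(C)nn3-c3ccccc3)c(-c3ccccc3C#N)c2C#N)cc1` gives 2400 nM, while compound 2 `Cc1ccc(-c2nc3c(c(C)nn3-c3ccccc3)c(-c3ccccc3O)c2C#N)cc1` gives 26000 nM. Compound 2 therefore holds the higher of the two numbers, and its gap to compound 1 lies beyond the usual scatter of repeated measurements, but the two structures differ in more than one place, so no single change can be tied to that gap.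

Compound 3 `CCc1cccc(-c2nc3c(c(C)nn3-c3ccccc3)c(-c3ccccc3O)c2C#N)c1` has not yet been measured in this assay. It differs from compound 2 in one place: 3-ethylphenyl in place of 4-methylphenyl on an aromatic carbon. Among the measured compounds shown here, no measured pair shows this kind of exchange, so its effect is unknown here. The step from compound 2 to compound 3 is expected to be small, a 1.4-fold lower number from compound 2 to compound 3 (0.16 log units; within the scatter), within the scatter. Because compound 2 gives 26000 nM, compound 3 is estimated at 18000 nM, with a range from 7000 nM to 45000 nM.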

Compound 3, solubility: 11000 nM
For compound 3 the middle estimate is 1.6-fold (0.21 log units) above the measured one; the measured number falls inside the stated range.
By their numbers in this assay, from the lowest: compound 1; then compound 3; then compound 2.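

In this assay, among the compounds shown here, putting 3-ethylphenyl in place of 4-methylphenyl on the aromatic carbon next to the ring nitrogen gives a 2.4-fold lower number from compound 2 to compound 3 (0.37 log units; beyond the scatter), the first single change that can be read at this position, and it shows that the number here responds to the choice of this phenyl group. The exchange alters two things together, the alkyl group from methyl to ethyl and its place on the phenyl ring, so the step belongs to the whole exchange and not to either part alone. Nothing measured here gives a reason for the step.

The compounds shown leave open how 3-methylphenyl or 4-ethylphenyl would compare, which would separate the two parts of the exchange. They also leave open how a phenyl ring carrying an amine or a carboxylic acid would read at this position.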